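Estimating a butyl amide from a methylpiperidine amide

The source may hold more compounds than are shown below. What is called first, only, known or untested is meant among the compounds shown, and "the series" means these compounds.

Compound 1 `Nc1sc(-c2ccc(Cl)cc2)c(-c2ccc(Cl)cc2)c1C(=O)N1CCCCC1` reads 14300 nM
Compound 2 `CC1CCN(C(=O)c2c(N)sc(-c3ccc(Cl)cc3)c2-c2ccc(Cl)cc2)CC1` reads 5750 nM
Compound 3 `CCOC(=O)Nc1sc(-c2ccc(Cl)cc2)c(-c2ccc(Cl)cc2)c1C(=O)NC1CC1` reads 27600 nM

These three were tested in a functional assay on PC-3 cells (Homo sapiens) for inhibition, read by sulforhodamine B assay, with a stated time of 72 h (a higher number here means a weaker inhibitor, a lower number a stronger inhibitor), and compound 2 has the lowest number, which makes it the strongest inhibitor of the three. Both of the other compounds lie beyond the scatter from it.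

The next compound, compound 4 `CCCCNC(=O)c1c(N)sc(-c2ccc(Cl)cc2)c1-c1ccc(Cl)cc1`, carries butylamino in place of 4-methylpiperidin-1-yl on a carbonyl carbon. Among the measured compounds shown here, only one measured step concerns this group. Methyl in place of hydrogen on a saturated ring carbon gave a 2.5-fold lower number from compound 1 to compound 2 (0.40 log units; beyond the scatter) and that step was modest. For the measured compounds named here, compound 4 loses the ring altogether, and no measured pair shows such a change directly. Going by the values given here, compound 3, the only measured compound with an amide hydrogen, has the highest number at 27600 nM but it also differs from the others elsewhere, so it offers only a faint hint. A modest move toward a higher number, meaning a weaker inhibitor, is therefore expected in this assay for this change. The expected move is a 1.6-fold higher number from compound 2 to compound 4 (0.19 log units; within the scatter) and it remains uncertain. For compound 4 the estimate is 9000 nM (expected range 3500 nM to 23000 nM).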

Compound 4, half-maximal inhibitory concentration: 17800 nM
The estimate for compound 4 lay 2.0-fold (0.30 log units) below the measured number; low and high end bracket the measured number.
By their numbers in this assay, from the lowest: compound 2; then compounds 1, 4 and 3 (each within the scatter of the next).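

Set against the methyl-bearing ring, the open chain gives a weaker inhibitor in this assay (a 3.1-fold higher number from compound 2 to compound 4 (0.49 log units; beyond the scatter)). Set against the plain ring, the same kind of swap gives a step within the scatter (a 1.2-fold higher number from compound 1 to compound 4 (0.10 log units; within the scatter)), so butylamino and piperidin-1-yl cannot be told apart on this carbonyl carbon, and opening the ring by itself shows no measurable cost. The advantage at this position therefore rests so far on compound 2 alone, and nothing available explains it.

The compounds shown leave open whether an ethyl or hydroxyl group on the saturated ring would match or outdo the methyl. They also leave open whether a propyl or pentyl chain on the amide nitrogen would read any differently from butylamino.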